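The source may report more compounds than this note shows. Statements on the series, on what has been measured and on what is new or still open speak of the compounds shown alone.

Of the compounds shown here, three built on one shared core have been measured in a functional assay on B16 cells (Mus musculus) for inhibition; on this read-out higher numbers stand for weaker inhibition and lower numbers for stronger inhibition. Compound 1 `COc1cc(/C=C/C(=O)c2cccc(NC(=O)c3c(Cl)cccc3Cl)c2)ccc1O` gives 1.58 ug/mL. Compound 2 `COc1cc(/C=C/C(=O)c2cccc(NC(=O)c3cc(Cl)cc(Cl)c3)c2)ccc1O` gives 4.83 ug/mL. Compound 3 `COc1cc(/C=C/C(=O)c2cccc(NC(=O)c3ccco3)c2)ccc1O` gives 5.46 ug/mL. On these numbers compound 2 stands second highest of the three: the number of compound 3 lies within the scatter of it, as seen in a 1.1-fold higher number from compound 2 to compound 3 (0.05 log units; within the scatter), while compound 1 stands furthest from it, with a 3.1-fold higher number from compound 1 to compound 2 (0.49 log units; beyond the scatter).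

Compound 4 `COc1cc(/C=C/C(=O)c2cccc(NC(=O)c3ccc(Cl)c(Cl)c3)c2)ccc1O` has not yet been measured in this assay. It differs from compound 2 in one place: 3,4-dichlorophenyl in place of 3,5-dichlorophenyl on a carbonyl carbon. Among the measured compounds shown here, the step that bears most on this change is the one from compound 1 to compound 2, where the two chlorines were also rearranged on the same ring and the outcome was a 3.1-fold higher number from compound 1 to compound 2 (0.49 log units; beyond the scatter), a modest shift. The step from compound 2 to compound 3, a 1.1-fold higher number from compound 2 to compound 3 (0.05 log units; within the scatter), shows that a replacement of the whole group at this carbonyl carbon can also leave the number essentially unchanged. Nothing measured tells directly how a 3,4-dichlorophenyl behaves here, so an expectation of little or no change beyond the scatter, with a modest shift in either direction possible, seems the most defensible. Compound 4 is therefore estimated at 4 ug/mL, within a range from 1.8 ug/mL to 9 ug/mL. This estimate means a step of a 1.2-fold lower number from compound 2 to compound 4 (0.08 log units; within the scatter), expected to lie within the scatter.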

Compound 4, half-maximal inhibitory concentration: 3.88 ug/mL
For compound 4 the middle estimate is 1.0-fold (0.01 log units) above the measured one, and the stated range covers the measured number.
By their numbers in this assay, from the lowest: compound 1; then compounds 4, 2 and 3 (each within the scatter of the next).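

In this assay, the 3,4-dichlorophenyl on this carbonyl carbon cannot be told apart from the 3,5-dichlorophenyl, with a 1.2-fold lower number from compound 2 to compound 4 (0.10 log units; within the scatter), or from the furan-2-yl, with a 1.4-fold lower number from compound 3 to compound 4 (0.15 log units; within the scatter). The position therefore tolerates a second rearrangement of the two chlorines, and a whole-group replacement, with no step beyond the scatter among these three groups, while the 2,6-dichlorophenyl alone stands apart, now also with a 2.5-fold higher number from compound 1 to compound 4 (0.39 log units; beyond the scatter). Nothing at hand accounts for why that one arrangement of the chlorines gives the strongest inhibition of the four.

The compounds shown leave open whether a single chlorine would be enough to reach the number of the 2,6-dichlorophenyl, and how a plain phenyl, a monochlorophenyl or a methoxyphenyl on this carbonyl carbon would compare. They also leave open how the amide-type nitrogen, or the rest of the shared core, responds to change, since every compound here differs only in the group on this carbonyl carbon.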